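The source may hold more compounds than are shown below. What is called first, only, known or untested is meant among the compounds shown, and "the series" means these compounds.

Compound 2 `c1ccc(-c2cn3ccnc3c(-c3ccc4ncn(C5CCCCC5)c4c3)n2)cc1` stands highest of the two numbers measured in a functional assay on A549 cells (Homo sapiens) for inhibition, read by sulforhodamine B assay, with a stated time of 48 h, tested at 10 uM (a higher number here means more inhibition at the concentration tested (going by the name of the read-out), a lower number less inhibition), where compound 2 gives 33.3%. Its nearest neighbour is compound 1 `Brc1cn2ccnc2c(-c2ccc3ncn(C4CCCCC4)c3c2)n1`, which in this assay gives 9.36%. Within the data shown here, the single measured step, a number 23.9 percentage points higher from compound 1 to compound 2 (beyond the scatter), phenyl in place of bromo on an aromatic carbon, lies beyond the scatter. Compound 3 `COc1ccc(-c2cn3ccnc3c(-c3ccc4ncn(C5CCCCC5)c4c3)n2)cc1` differs from compound 2 by methoxy in place of hydrogen on an aromatic carbon. Among the measured compounds shown here, no measured step bears directly on this change: the only known step concerns a phenyl replacing a bromo, a different kind of alteration, and it offers no guide to what a methoxy on that phenyl will do. Compound 3 is therefore expected to stay close to compound 2, with a step of a number 1.7 percentage points higher from compound 2 to compound 3 (within the scatter) that is not expected to exceed the scatter. The estimate for compound 3 in this assay is 35%, with a range from 15% to 55%.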

Compound 3, a percentage reported as inhibition, at one concentration (the size of the read-out at that concentration, not a potency): 68.6%
Compound 3: middle estimate off by 33.6 percentage points, on the low side; measured number above the stated range.
By their numbers in this assay, from the lowest: compound 1; then compound 2; then compound 3.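

In this assay, methoxy in place of hydrogen on the phenyl ring, para to a large group, gives a number 35.3 percentage points higher from compound 2 to compound 3 (beyond the scatter) and is a large step, whereas the earlier phenyl-for-bromo step was modest. Measured from the bromo compound, the full change to 4-methoxyphenyl gives a number 59.2 percentage points higher from compound 1 to compound 3 (beyond the scatter) and is also large, so this position on the added ring responds strongly to a small substituent in this assay. What lies behind the size of this step cannot be said from the information available.

Going by these compounds, it remains open whether this response is specific to methoxy or would also appear with a hydroxyl group, an amine or a longer chain such as ethoxy at the same carbon. On these data alone, the effect of methoxy on the other carbons of that phenyl ring also remains open.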